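The compounds below may be only part of what the source reports. "The series", "measured", "known", "first", "only" and "open" are said of these compounds alone.

Measured in an ADME assay on microsomes from liver (Mus musculus) for metabolic stability, read by LC-MS, with a stated time of 60 min; on this read-out higher numbers stand for a more stable compound and lower numbers for a less stable compound
- compound 1 `NC(=O)c1cnc2c(c1)CCN2` gives 89%
- compound 2 `Cc1c(C(N)=O)cnc2c1CCN2` gives 47%

Among the measured compounds shown here, compound 2 holds the lower of the two numbers, with compound 1 as its only neighbour. Compound 3 `NC(=O)c1cnc2c(c1Cl)CCN2` differs from it by chloro in place of methyl on an aromatic carbon with chloro in place of methyl on an aromatic carbon, opposite the ring nitrogen. For the measured compounds named here, one measured step bears on this carbon: a number 42 percentage points lower from compound 1 to compound 2 (beyond the scatter) is large and beyond the scatter. Going by the values given here, no chloro compound has been measured, so this single step sets the scale. A partial recovery upward in this assay is expected. The estimate means a number 19 percentage points higher from compound 2 to compound 3 (beyond the scatter) as the expected change. Compound 3 is estimated at 66% with an expected range from 43% to 88% for now.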

Compound 3, percent of the compound remaining: 40%
Beside the measured number, compound 3's estimate is 26 percentage points above it; measured number outside the range, below it.
By their numbers in this assay, from the lowest: compounds 3 and 2 (each within the scatter of the next); then compound 1.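

In this assay, chloro in place of methyl on this aromatic carbon, opposite the ring nitrogen, gives a number 7 percentage points lower from compound 2 to compound 3 (within the scatter), so the two groups cannot be told apart here. Chloro in place of hydrogen gives a number 49 percentage points lower from compound 1 to compound 3 (beyond the scatter), so the large loss at this carbon is not confined to methyl. No evidence at hand bears on the reason for this loss. Open, from the compounds shown here alone, is whether fluoro, methoxy or an amine at this carbon would keep the number of the unsubstituted compound 1 or share the loss.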